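Para-methoxy on the terminal anilide: a small step expected

The compounds below may be only part of what the source reports. "The series", "measured", "known", "first", "only" and "open" are said of these compounds alone.

Measured compounds:
compound 1, `CN(C)C(=O)c1cc2cnc(Nc3ccc(NC(=O)C4(C(=O)Nc5ccccc5)CC4)cc3)nc2n1C1CCCC1`, 75%
compound 2, `CN(C)C(=O)c1cc2cnc(Nc3ccc(NC(=O)C4(C(=O)Nc5ccc(O)cc5)CC4)cc3)nc2n1C1CCCC1`, 93.6%
compound 3, `COc1cccc(NC(=O)C2(C(=O)Nc3ccc(Nc4ncc5cc(C(=O)N(C)C)n(C6CCCC6)c5n4)cc3)CC2)c1`, 77.2%

Within a functional assay on A549 cells (Homo sapiens) for inhibition, read by CCK-8 assay, with a stated time of 72 h, tested at 1 uM (on this read-out higher numbers stand for more inhibition of growth at the one concentration tested and lower numbers for less inhibition of growth), compound 1 gives the lowest of the three numbers: compound 3 lies within the scatter of it, while compound 2 stands clearly higher.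

Compound 4, `COc1ccc(NC(=O)C2(C(=O)Nc3ccc(Nc4ncc5cc(C(=O)N(C)C)n(C6CCCC6)c5n4)cc3)CC2)cc1`, is not yet measured. It differs from compound 1 in one place: methoxy in place of hydrogen on an aromatic carbon.

Going by the values given here, two measured steps bear on this. The step of a number 18.6 percentage points higher from compound 1 to compound 2 (beyond the scatter) places a hydroxy group on the same ring and raises growth inhibition modestly. The step of a number 2.2 percentage points higher from compound 1 to compound 3 (within the scatter) brings in the same methoxy group on that ring, though not at the position compound 4 carries it, and changes nothing beyond the scatter. The comparison a number 16.4 percentage points lower from compound 2 to compound 3 (beyond the scatter) shows that which group sits on the ring, and where, does matter. The methoxy of compound 4 shares the group of compound 3 and the place, para to a large group, of the hydroxy of compound 2, so an expected step of a number 7 percentage points higher from compound 1 to compound 4 (within the scatter), upward but small, seems reasonable.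

Compound 4 is therefore estimated at 82%, with a likely range from 70% to 92%.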

Compound 4, percent growth inhibition at one concentration: 74.4%
For compound 4 the middle estimate is 7.6 percentage points above the measured one, and the stated range covers the measured number.
By their numbers in this assay, from the lowest: compounds 4, 1 and 3 (each within the scatter of the next); then compound 2.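

The step of a number 0.6 percentage points lower from compound 1 to compound 4 (within the scatter) and the step of a number 2.8 percentage points lower from compound 3 to compound 4 (within the scatter) show that in this assay the 4-methoxyphenyl compound cannot be told apart from either the plain phenyl compound or the 3-methoxyphenyl compound. So, among these compounds, a methoxy group on this ring gives no shift beyond the scatter at either of the two places it occupies. The step of a number 19.2 percentage points lower from compound 2 to compound 4 (beyond the scatter) puts only a methyl on the oxygen of compound 2, and it shows that the higher number of compound 2 does not carry over to its methyl ether, even with the group in the same place, para to a large group. No measured information here says what lies behind this difference between the hydroxy and the methoxy compounds.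

As far as these compounds go, it remains open whether the higher number belongs to the hydroxy group alone or would also appear with another group in this place, such as an amine or a carboxylic acid. A 3-hydroxyphenyl ring would show whether the hydroxy group needs this place at all.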